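Replacing chloro with hydroxy on compound 3

The source may hold more compounds than are shown below. What is called first, only, known or untested is meant among the compounds shown, and "the series" means these compounds.

Measured so far in a functional assay on HT-1080 cells (Homo sapiens) for cytotoxicity, read by MTT assay, with a stated time of 72 h; on this read-out lower numbers stand for stronger inhibition and higher numbers for weaker inhibition:
- compound 1 `COc1cccc(/C=C2\CCC/C(=C\c3cccc(OC)c3OC)C2=O)c1`: 9900 nM
- compound 2 `COc1cccc(/C=C2\CCC/C(=C\c3cc(Cl)cc(Cl)c3)C2=O)c1OC`: 6100 nM
- compound 3 `COc1ccc(/C=C2\CCC/C(=C\c3ccc(Cl)cc3)C2=O)cc1OC`: 4800 nM

Compound 3, at 4800 nM, lies within the scatter of compound 2, at 6100 nM, so these two cannot be ordered. Its number is lower than that of compound 1, at 9900 nM, and this gap lies beyond the scatter.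

The next compound is compound 4 `COc1ccc(/C=C2\CCC/C(=C\c3ccc(O)cc3)C2=O)cc1OC`, with hydroxy in place of chloro on an aromatic carbon, para to a large group, the same difference reading 4-chlorophenyl to 4-hydroxyphenyl: hydroxy in place of chloro on an aromatic carbon.

Going by the values given here, no measured compound carries this hydroxy, and no measured step makes this exchange. Among the compounds with values here, the only single-place comparison is a 1.6-fold lower number from compound 1 to compound 2 (0.21 log units; within the scatter). Within the data shown here, it concerns a different replacement, so it gives weak guidance, and it offers no precedent for a large move. With so little evidence, no shift beyond the scatter is expected in this assay, and no direction can be favoured with confidence. The expected size of the change is a 1.0-fold higher number from compound 3 to compound 4 (0.02 log units; within the scatter). As far as these compounds go, the range is kept wide, since the hydroxy exchange itself is untested.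

For compound 4 the estimated value is 5000 nM, with an expected range from 1800 nM to 14000 nM.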

Compound 4, half-maximal inhibitory concentration: 16800 nM
Compound 4: the middle estimate sits 3.4-fold (0.53 log units) below what was measured; measured number outside the range, above it.
By their numbers in this assay, from the lowest: compounds 3, 2, 1 and 4 (each within the scatter of the next, the first and the last beyond it).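

In this assay, hydroxy in place of chloro on an aromatic carbon, para to a large group, gives a change beyond the scatter: a 3.5-fold higher number from compound 3 to compound 4 (0.54 log units; beyond the scatter). This is the first single-place step among the compounds shown to clear the scatter, since the only earlier step, the exchange between compound 1 and compound 2, stayed within it. The position is therefore not indifferent to what it carries: with the rest of the molecule held constant, 4-chlorophenyl is clearly preferred over 4-hydroxyphenyl on this read-out, although no measurement at hand says what lies behind the difference.

The compounds shown leave open whether the step follows from the departure of chloro or the arrival of hydroxy, and a fluoro group or an amine on the same aromatic carbon would help to separate the two. Also open, as far as these compounds go, is whether the same exchange gives a step of similar size and direction when the other side of the core carries different groups, as a single pair cannot show that it carries over.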